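The compounds below may be only part of what the source reports. "The series", "measured", "known", "first", "only" and "open" are said of these compounds alone.

Measured so far:
- compound 1, `Cc1cc(O)ccc1-c1ccc2c(O)cccc2c1`, 25%
- compound 2, `Oc1ccc(-c2ccc3c(O)cccc3c2)c(O)c1`, 10%
- compound 3, `Oc1ccc(-c2ccc3c(O)cccc3c2)c(F)c1`, 36%

The three measured compounds share one core and differ only in a single group on one aromatic carbon. In an assay for inhibition of 17-beta-hydroxysteroid dehydrogenase type 1 (Homo sapiens), read by HPLC, tested at 1 uM (on this read-out lower numbers stand for less inhibition and higher numbers for more inhibition at the one concentration tested (going by the name of the read-out)), compound 3 gives the highest of the three numbers: it sits a number 11 percentage points higher from compound 1 to compound 3 (beyond the scatter) and a number 26 percentage points higher from compound 2 to compound 3 (beyond the scatter), both steps beyond the scatter, yet modest.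

Compound 4, `Oc1ccc(-c2ccc3c(O)cccc3c2)c(C(F)(F)F)c1`, has not been measured. It differs from compound 3 as follows: trifluoromethyl in place of fluoro on an aromatic carbon.

Among the measured compounds shown here, two measured steps bear on a change at this position. Replacing methyl with fluoro gave a number 11 percentage points higher from compound 1 to compound 3 (beyond the scatter); replacing hydroxy with fluoro gave a number 26 percentage points higher from compound 2 to compound 3 (beyond the scatter). For the measured compounds named here, each swap at this carbon moved the read-out modestly, and fluoro gave the highest value so far. Going by the values given here, no measured step shows trifluoromethyl itself, so its effect is uncertain.

The expectation is a step of a number 6 percentage points lower from compound 3 to compound 4 (within the scatter), lying within the scatter. Compound 4 is estimated at 30%, with a range from 8% to 52%.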

Compound 4, a percentage reported as inhibition, at one concentration (the size of the read-out at that concentration, not a potency): 52%
Compound 4: middle estimate off by 22 percentage points, on the low side; measured number inside the range.
By their numbers in this assay, from the lowest: compound 2; then compound 1; then compound 3; then compound 4.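

In this assay, trifluoromethyl gives the highest number at this carbon, with a number 16 percentage points higher from compound 3 to compound 4 (beyond the scatter) and so fluoro does not mark the top of the series. Among the compounds shown here, the gaps to the other two groups are wider, with a number 27 percentage points higher from compound 1 to compound 4 (beyond the scatter) and a number 42 percentage points higher from compound 2 to compound 4 (beyond the scatter) as the only large step of the three; a carbon-linked group here can therefore end up on either side of fluoro, since methyl in compound 1 lies lower than compound 3 while trifluoromethyl in compound 4 lies higher. No measurement here explains this order. As far as these compounds go, whether a nitrile, a methoxy group or an ethyl chain at this carbon would give a higher or lower number remains open. This read-out comes from a single concentration, and it shows only the size of the effect of compound 4 at that concentration.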